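Swapping a Halogen for a Nitrile on the Shared Core

This account rests on a few compounds, and the source may have more. Where it says the series, first, only, none or still open, it means among the compounds named here.

Of the compounds shown here, two with one shared core have been measured so far. Compound 1 `Cc1ccn2nc(S(=O)(=O)Nc3c(F)ccc4cccnc34)nc2n1` carries a fluoro group, and in an assay for inhibition of acetolactate synthase (Nicotiana tabacum) (on this read-out lower numbers stand for stronger inhibition and higher numbers for weaker inhibition), compound 1 gives 17.1 nM. Compound 2 `Cc1ccn2nc(S(=O)(=O)Nc3c(Cl)ccc4cccnc34)nc2n1` carries a chloro group at the same place, and in this assay compound 2 gives 37.2 nM. Going by the values given here, the single step between them, a 2.2-fold higher number from compound 1 to compound 2 (0.34 log units; beyond the scatter), moves the number upward, so compound 2 stands with the highest number of the two, with compound 1 as its only neighbour.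

Compound 3 `Cc1ccn2nc(S(=O)(=O)Nc3c(C#N)ccc4cccnc34)nc2n1` has not yet been measured. It differs from compound 2 in one place: cyano in place of chloro on an aromatic carbon. Among the compounds with values here, only one measured step exists, and it concerns a different exchange, one halogen for another; it was modest in size. Nothing measured here speaks to a cyano group, so the expectation rests on compound 2 alone and is wide. Compound 3 is expected to land near compound 2, with a 1.2-fold lower number from compound 2 to compound 3 (0.09 log units; within the scatter) as the estimated step, and the estimated value for compound 3 is 30 nM, within a range from 10 nM to 100 nM.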

Compound 3, half-maximal inhibitory concentration: 64 nM
Compound 3: the middle estimate sits 2.1-fold (0.33 log units) below what was measured; the measured number falls inside the stated range.
By their numbers in this assay, from the lowest: compound 1; then compounds 2 and 3 (each within the scatter of the next).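

In this assay, the exchange of chloro for cyano gives a 1.7-fold higher number from compound 2 to compound 3 (0.24 log units; within the scatter) and so stays inside the usual spread of repeat measurements, which means that this aromatic carbon does not separate the two groups on this read-out, even though cyano has 2 heavy atoms, a triple bond and 1 hydrogen-bond acceptor where chloro has 1 heavy atom and 0 acceptors. The exchange of fluoro for cyano gives a 3.7-fold higher number from compound 1 to compound 3 (0.57 log units; beyond the scatter) and lies beyond that spread, so among the three groups fluoro alone stands apart, and compound 1 is the strongest inhibitor of the three in this assay. No measurement is at hand that could explain why these groups rank as they do.

What the compounds shown leave open is how this position behaves with a group of another kind, such as an amine, a methoxy group or a carboxylic acid, or with plain hydrogen in place of any halogen or nitrile. They also leave open whether the same order of fluoro, chloro and cyano would hold on a core changed elsewhere, since all three share one core.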